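Swapping the Methyl-Bearing Ring for a Nitrile-Bearing Ring

The compounds below may be only part of what the source reports. "The series", "measured", "known", "first", "only" and "open" are said of these compounds alone.

Measured compounds:
- compound 1, `CC/C(=C(/c1ccc(/C=C/C(=O)O)cc1)c1cc2ccccc2[nH]1)c1ccccc1`, 108 nM
- compound 2, `CC/C(=C(/c1ccc(/C=C/C(=O)O)cc1)c1cc2ccccc2[nH]1)c1ccccc1C`, 33 nM

In a functional assay on MCF7 cells (Homo sapiens) for inhibition (a higher number here means a weaker inhibitor, a lower number a stronger inhibitor), compound 2 gives 33 nM, the lowest of the two numbers seen so far. Its nearest neighbour is compound 1, which in this assay gives 108 nM. For the measured compounds named here, the single step between them, a 3.3-fold lower number from compound 1 to compound 2 (0.51 log units; beyond the scatter), shows that adding a methyl to the phenyl ring brought a modest gain beyond the scatter.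

Compound 3, `CC/C(=C(/c1ccc(/C=C/C(=O)O)cc1)c1cc2ccccc2[nH]1)c1ccc(C#N)cc1`, has not yet been measured in this assay. It differs from compound 2 in one place: 4-cyanophenyl in place of 2-methylphenyl on a double-bonded chain carbon bound to a double-bonded chain carbon and a saturated chain carbon. Going by the values given here, the change therefore undoes the methyl addition that helped in the step from compound 1 to compound 2, and at the same time introduces a nitrile on the ring, for which no measured step exists. Only the methyl step bears on the expectation, and it argues for a drift back toward compound 1, while the nitrile remains an unknown. The expected step is therefore a 2.4-fold higher number from compound 2 to compound 3 (0.38 log units; beyond the scatter), a modest weakening. Compound 3 is estimated at 80 nM, within a range of 25 nM to 250 nM.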

Compound 3, half-maximal inhibitory concentration: 278 nM
Estimate against measurement, compound 3: 3.5-fold (0.54 log units) below, outside the stated range (above it).
By their numbers in this assay, from the lowest: compound 2; then compound 1; then compound 3.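

The ring on the double-bonded chain carbon turns out to respond in both directions in this assay: the methyl step was a gain, a 3.3-fold lower number from compound 1 to compound 2 (0.51 log units; beyond the scatter), whereas adding a nitrile to this ring costs activity, a 2.6-fold higher number from compound 1 to compound 3 (0.41 log units; beyond the scatter). The nitrile is therefore no neutral passenger, and the direct swap of 2-methylphenyl for 4-cyanophenyl, an 8.4-fold higher number from compound 2 to compound 3 (0.93 log units; beyond the scatter), is roughly what the two single steps add up to, since it gives up the methyl gain and takes on the nitrile loss together. Nothing available explains why either group shifts the number as it does.

For the compounds shown here, each of the two groups appears at only one place on the ring, so these compounds cannot separate the effect of the group itself from the effect of where it sits. They also leave open how other groups on this ring, such as a methoxy group or a chlorine atom, would behave, and whether any of them would improve on compound 2.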